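Cyclobutylmethyl in place of cyclopentyl on a carbonyl carbon

The source may hold more compounds than are shown below. What is called first, only, known or untested is meant among the compounds shown, and "the series" means these compounds.

Measured so far in a physicochemical assay for solubility, read by HPLC, in phosphate buffer, measured as kinetic solubility, at pH 7.4 (on this read-out lower numbers stand for lower solubility and higher numbers for higher solubility), as follows
- Compound 1 `CCCC(=O)c1cc(-c2ccc(S(N)(=O)=O)cc2)n(-c2ccc(Cl)cc2)n1` gives 25800 nM
- Compound 2 `CC(C)(C)C(=O)c1cc(-c2ccc(S(N)(=O)=O)cc2)n(-c2ccc(Cl)cc2)n1` gives 6600 nM
- Compound 3 `NS(=O)(=O)c1ccc(-c2cc(C(=O)C3CCCC3)nn2-c2ccc(Cl)cc2)cc1` gives 4600 nM

Compound 3 shares the low end of the three numbers, with a 1.4-fold lower number from compound 2 to compound 3 (0.16 log units; within the scatter) and with a 5.6-fold lower number from compound 1 to compound 3 (0.75 log units; beyond the scatter) on the other side. Next in line for this assay is compound 4 `NS(=O)(=O)c1ccc(-c2cc(C(=O)CC3CCC3)nn2-c2ccc(Cl)cc2)cc1` and the change is cyclobutylmethyl in place of cyclopentyl on a carbonyl carbon or, in words, cyclobutylmethyl in place of cyclopentyl on a carbonyl carbon. The two have the same atoms, joined differently.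

All three measured steps sit at this same place. Two start from propyl and are modest, namely a 3.9-fold lower number from compound 1 to compound 2 (0.59 log units; beyond the scatter) and a 5.6-fold lower number from compound 1 to compound 3 (0.75 log units; beyond the scatter) in that order of mention. Among the compounds with values here, the third, a 1.4-fold lower number from compound 2 to compound 3 (0.16 log units; within the scatter) and no more, is the closest precedent, as it swaps one of these larger groups for another. Within the data shown here, no measured compound carries cyclobutylmethyl, so the reading rests on these steps alone. On that basis no step beyond the scatter is the main expectation, with a slight lean to a higher number. Compound 1 at 25800 nM leaves room upward, so the expected range is wider on that side.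

The expected move is a 1.5-fold higher number from compound 3 to compound 4 (0.18 log units; within the scatter) as an estimate. For compound 4 the estimated value is 7000 nM with an expected range of 3000 nM to 18000 nM for this estimate.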

Compound 4, solubility: 4300 nM
For compound 4 the middle estimate is 1.6-fold (0.21 log units) above the measured one, and the stated range covers the measured number.
By their numbers in this assay, from the lowest: compounds 4, 3 and 2 (each within the scatter of the next); then compound 1.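

In this assay the same five carbons rearranged from cyclopentyl to cyclobutylmethyl give a 1.1-fold lower number from compound 3 to compound 4 (0.03 log units; within the scatter) and so leave the read-out inside the scatter, which shows that this position tolerates a change of ring size with a methylene link at the carbonyl carbon without a readable shift. Within the data shown here, with a 1.5-fold lower number from compound 2 to compound 4 (0.19 log units; within the scatter) as well, tert-butyl, cyclopentyl and cyclobutylmethyl now form a set of three groups that cannot be told apart here, while a 6.0-fold lower number from compound 1 to compound 4 (0.78 log units; beyond the scatter) is the one new step beyond the scatter and leaves propyl in compound 1 alone at the high end. Nothing at hand offers an explanation for this grouping or for the distance to compound 1.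

Still open, on these data alone, is whether the level shared by compounds 2, 3 and 4 carries over to groups on the carbonyl carbon that hold an amine, a morpholine or a carboxylic acid. Also open, as far as these compounds go, is whether a longer straight chain than propyl, such as hexyl, stays near compound 1 or joins the other three.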